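Methoxy added to compound 1: expected growth inhibition

The source may report more compounds than this note shows. Statements on the series, on what has been measured and on what is new or still open speak of the compounds shown alone.

Measured so far in a functional assay on THP-1 cells (Homo sapiens) for inhibition, read by sulforhodamine B assay, with a stated time of 48 h, tested at 50 uM; a higher number here means more inhibition of growth at the concentration tested, a lower number less inhibition of growth:
compound 1, `COc1cc(/C=C/C(=O)/C=C/c2ccccc2)ccc1OCc1cn(CCCOc2cc(=O)oc3ccccc23)nn1` — 48%
compound 2, `COc1ccccc1/C=C/C(=O)/C=C/c1ccc(OCc2cn(CCOc3cc(=O)oc4ccccc34)nn2)c(OC)c1` — 75%
compound 3, `COc1ccc(/C=C/C(=O)/C=C/c2ccc(OCc3cn(CCCCOc4cc(=O)oc5ccccc45)nn3)c(OC)c2)cc1OC` — 59%

Compound 1 stands lowest of the three numbers. Compound 3 is nearest to it, and that gap is already beyond the usual scatter; compound 2 is furthest from compound 1, again beyond the scatter. For the measured compounds named here, no pair of the measured compounds differs in only one place, so no single step can be read from them: compounds 2 and 3 differ from compound 1 both in the substitution of the ring at the far end of the dienone and in the length of the chain that carries the other ring system. The two effects are therefore not separable from what is measured.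

The unmeasured compound 4, `COc1cccc(/C=C/C(=O)/C=C/c2ccc(OCc3cn(CCCOc4cc(=O)oc5ccccc45)nn3)c(OC)c2)c1`, differs from compound 1 as follows: methoxy in place of hydrogen on an aromatic carbon. Both measured compounds that carry methoxy on that ring give higher numbers than compound 1, but each also carries a different chain length, so this is suggestive only. A modest upward step from compound 1 to compound 4 is expected, a number 8 percentage points higher from compound 1 to compound 4 (within the scatter), quite possibly not beyond the scatter. Compound 4 is estimated at 56% in this assay, with a range from 40% to 72%.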

Compound 4, percent growth inhibition at one concentration: 58%
The estimate for compound 4 lay 2 percentage points below the measured number, and the stated range covers the measured number.
By their numbers in this assay, from the lowest: compounds 1, 4 and 3 (each within the scatter of the next, the first and the last beyond it); then compound 2.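

For the compounds shown here, compound 1 and compound 4 form the first pair that differs in one place only, so the change from phenyl to 3-methoxyphenyl can be read with the chain held constant: in this assay, the step is a number 10 percentage points higher from compound 1 to compound 4 (within the scatter). At this position, meta to a large group, methoxy in place of hydrogen therefore gives no change that can be separated from the scatter, so this pair alone does not establish a gain from the substitution, though the position does accept methoxy without a loss beyond the scatter. No measured property or other supporting data bear on this result.

Steps involving compound 2 or compound 3 cannot be read, as each differs from the others in more than one place, so the contribution of chain length at a fixed ring substitution remains open. Also open, going by these compounds, is whether a hydroxyl, a fluorine or a dimethylamino group at this same position, or a longer chain such as ethoxy in place of methoxy, would give a step beyond the scatter.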